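The compounds below may be only part of what the source reports. "The series", "measured", "known", "first", "only" and "open" are said of these compounds alone.

The study gathers three compounds built on one shared core, and a fourth that has not yet been tested. In an ADME assay on L02 cells (Homo sapiens) for cytotoxicity, read by CCK-8 assay, with a stated time of 6 days (on this read-out lower numbers stand for stronger inhibition and higher numbers for weaker inhibition), compound 1 `COC(=O)/C=C/C(=O)N[C@@H](C)Cn1ccc(-c2ccc(C#N)c(Cl)c2)n1` is recorded as "not determined" (no result reported), and compound 2 `CC(=O)c1ccc(S(=O)(=O)N[C@@H](C)Cn2ccc(-c3ccc(C#N)c(Cl)c3)n2)cc1` is recorded as "not determined" (no result reported), so no result exists for either of them. Among the measured compounds shown here, compound 3 `C[C@@H](Cn1ccc(-c2ccc(C#N)c(Cl)c2)n1)Nc1cccnc1` is the only member with a reading: in this assay compound 3 gives > 30000 nM, which is a limit of the assay and not a number. Of the three entries shown, then, one sits at the limit of > 30000 nM in this assay, at which 1 of the 3 values shown sits, and the other two carry no number at all, so compound 3 stands as the sole anchor, and only a limit at that.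

Compound 4 `Cc1ccnc(N[C@@H](C)Cn2ccc(-c3ccc(C#N)c(Cl)c3)n2)n1` differs from compound 3 in a single place, namely (4-methylpyrimidin-2-yl in place of pyridin-3-yl on an amine nitrogen). For the measured compounds named here, no pair of measured compounds shows how a change of this kind moves the reading in this assay, so there is no step to lean on. Since compound 3 is known only by its limit, the step from compound 3 to compound 4 is expected to stay within the scatter, that is a number no higher from compound 3 to compound 4 (the limit leaves the size open), with no direction claimed. Compound 4 is therefore estimated to come out at 30000 nM, within a range of 15000 nM to 60000 nM, most likely reported again as a limit.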

Compound 4, half-maximal inhibitory concentration: > 30000 nM
Compound 4: no number, only a limit; the forecaster's own chance of this, stated with the estimate: 85%; the middle value sits exactly at the limit.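

In this assay, compound 4 is recorded only as a limit, as compound 3 is, so no step can be read between compound 3 and compound 4: the limit of > 30000 nM in this assay, at which 2 of the 4 values shown sit. The compounds shown leave open whether 4-methylpyrimidin-2-yl in place of pyridin-3-yl on an amine nitrogen changes the reading at all.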